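Adding a Methoxy Group: From Compound 3 to Compound 4

A few compounds are considered here, and "the series" means these few. Any claim that something is new, unique, unknown or untested is made for them only; others in the source may bear on it.

Of the compounds shown here, three have been measured in a functional assay on SW1573 cells (Homo sapiens) for inhibition, read by sulforhodamine B assay, with a stated time of 48 h; a lower number here means a stronger inhibitor of growth, a higher number a weaker inhibitor of growth. Compound 1 `CC(=O)OC/C(=C\c1ccccc1)C(=O)c1ccccc1` gives 4800 nM. Compound 2 `CC(=O)OC/C(=C\c1ccccc1F)C(=O)c1ccccc1` carries a fluorine on an aromatic carbon where compound 1 has hydrogen. Compound 2 gives 6100 nM, and the step of a 1.3-fold higher number from compound 1 to compound 2 (0.10 log units; within the scatter) lies within the scatter. Compound 3 `C=C(C/C(=C\c1ccccc1)C(=O)c1ccccc1)C(=O)c1ccccc1` gives 3000 nM, the lowest of the three numbers; its gap to compound 1 lies within the scatter, and only its gap to compound 2 lies beyond it.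

Compound 4 `C=C(C/C(=C\c1ccc(OC)cc1)C(=O)c1ccccc1)C(=O)c1ccccc1` has not yet been measured. It differs from compound 3 by a single change: methoxy in place of hydrogen on an aromatic carbon. For the measured compounds named here, the only measured step of a similar kind, a small group put on an aromatic carbon in place of hydrogen, is a 1.3-fold higher number from compound 1 to compound 2 (0.10 log units; within the scatter), which stayed within the scatter. On that basis compound 4 is expected to sit close to compound 3, with an estimated step of no change at the digits printed from compound 3 to compound 4 (within the scatter) that does not go beyond the scatter. In this assay compound 4 is therefore estimated at about 3000 nM, expected to fall between 1500 nM and 6000 nM.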

Compound 4, concentration for 50% growth inhibition: 450 nM
Beside the measured number, compound 4's estimate is 6.7-fold (0.82 log units) above it; measured number below the stated range.
By their numbers in this assay, from the lowest: compound 4; then compounds 3, 1 and 2 (each within the scatter of the next, the first and the last beyond it).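

In this assay, methoxy in place of hydrogen on an aromatic carbon, para to a large group, gives a 6.7-fold lower number from compound 3 to compound 4 (0.82 log units; beyond the scatter), which shows that one small change at this position can clearly move the number. For the compounds shown here, the only earlier one-place step, a 1.3-fold higher number from compound 1 to compound 2 (0.10 log units; within the scatter), put fluoro on an aromatic carbon of a different compound and stayed within the scatter, so a change on an aromatic carbon does not always leave the number in place. Nothing available here explains why methoxy has this effect.

As far as these compounds go, whether the drop needs methoxy itself stays open: a hydroxy group, an ethoxy chain or an amine at this same place would test that. From the compounds shown here alone, it also remains open whether methoxy at this place would lower the number on the core of compound 1.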